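The source may report more compounds than this note shows. Statements on the series, on what has been measured and on what is new or still open speak of the compounds shown alone.

Two compounds share one core and differ only in what hangs from the sulfur. Compound 1 `Cc1cc(Nc2cc(-c3cccs3)[nH]n2)n2nc(SCc3ccc(Br)cc3)nc2n1` carries a brominated benzyl group there, while compound 2 `Cc1cc(Nc2cc(-c3ccccc3)[nH]n2)n2nc(SCCCc3ccccc3)nc2n1` carries a 3-phenylpropyl chain. In an ADME assay on GES1 cells (Homo sapiens) for inhibition, read by MTT assay, with a stated time of 72 h (on this read-out higher numbers stand for weaker inhibition and lower numbers for stronger inhibition), compound 2 gives 40200 nM. In this assay compound 1 gives 38700 nM, a number that sits within the scatter of the number for compound 2, so the two cannot be told apart on these data.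

Compound 3 `Cc1cc(Nc2cc(-c3ccccc3)[nH]n2)n2nc(SCC3CC3)nc2n1` keeps the core of compound 2 and changes the sulfur chain: cyclopropyl in place of phenethyl on a saturated chain carbon bound to a sulfur. Within the data shown here, with only two measured compounds and no step between them to lean on, the expectation rests on the change alone: the step of a 1.2-fold higher number from compound 2 to compound 3 (0.08 log units; within the scatter) is expected to be small, if anything toward weaker inhibition, and not clearly beyond the scatter. In this assay compound 3 is therefore estimated at 48000 nM, with a plausible range from 20000 nM to 110000 nM.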

Compound 3, half-maximal inhibitory concentration: > 50000 nM
Compound 3 gave a limit, no number; the forecaster's own chance of this, stated with the estimate: 20%; middle value at least 1.0-fold (0.01 log units) away from the limit.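

In this assay compound 3 gives > 50000 nM, which is a limit of the assay and not a number. Putting cyclopropyl in place of phenethyl on a saturated chain carbon bound to a sulfur gives an at least 1.2-fold higher number from compound 2 to compound 3 (0.09 log units; that floor lies within the scatter), so this first single change at the position shows no sign of stronger inhibition, even though the entering group has 3 heavy atoms against 8 for the one that leaves. Only a floor can be given for the step, so its true size stays unknown, and the floor alone does not separate the two compounds: the limit of > 50000 nM in this assay, at which 1 of the 3 values shown sits.

As far as these compounds go, whether an amine or a carboxylic acid at the end of the sulfur chain would shift the inhibition stays open. So does the effect of a longer chain ending in cyclopropyl.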